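This account rests on a few compounds, and the source may have more. Where it says the series, first, only, none or still open, it means among the compounds named here.

Measured so far:
- Compound 1 `Cc1ccc2[nH]c(=O)c(CN(CCCO)Cc3ccc(C(C)(C)C)cc3)cc2c1`: in a toxicity assay on MDCK cells (Canis lupus familiaris) for cytotoxicity, read by crystal violet staining, with a stated time of 48 h (on this read-out lower numbers stand for higher toxicity in this test and higher numbers for lower toxicity in this test), compound 1 gives > 10000 nM, a limit of the assay rather than a number.
- Compound 2 `CCCOc1ccc(CN(Cc2ccc(C(C)(C)C)cc2)Cc2cc3cc(C)ccc3[nH]c2=O)cc1`: in this assay compound 2 gives > 5000 nM, again a limit of the assay and not a number.

Compound 2 thus stands at a limit, with no measured number of its own. Among the measured compounds shown here, the only step within the set, a step that the two limits leave unreadable from compound 1 to compound 2, cannot be read because the limit of > 10000 nM in this assay, at which 1 of the 2 values shown sits, and the limit of > 5000 nM in this assay, at which 1 of the 2 values shown sits, are both limits.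

Compound 3 `Cc1ccc2[nH]c(=O)c(CN(Cc3ccc(OCCO)cc3)Cc3ccc(C(C)(C)C)cc3)cc2c1` is not yet measured. It differs from compound 2 by hydroxy in place of methyl on a saturated chain carbon, two bonds along the chain from an oxygen on an aromatic ring. For the measured compounds named here, no readable step bears on this change; the one step measured touches the same amine substituent but yields no size. Compound 3 is therefore expected to remain at the limit, with a step that the limit leaves unreadable from compound 2 to compound 3 no step beyond the scatter. The estimate for compound 3 is 10000 nM, within 4000 nM to 30000 nM, most likely again reported only as a limit.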

Compound 3, half-maximal cytotoxic concentration: > 5000 nM
Compound 3: no number, only a limit; the forecaster's own chance of this, stated with the estimate: 80%; the middle value is on the limit's open side.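

The steps among compound 1, compound 2 and compound 3 cannot be read in this assay, as all three values are limits of the assay and not numbers. The compounds shown leave open where each half-maximal cytotoxic concentration lies and whether hydroxy in place of methyl changes it.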